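A few compounds are considered here, and "the series" means these few. Any claim that something is new, unique, unknown or untested is made for them only; others in the source may bear on it.

Measured so far:
Compound 1 `O=C(O)c1ccccc1-c1ccc(CCc2ncc(CC3CCCCC3)[nH]2)cc1` — 41 nM
Compound 2 `CCCCc1cnc(CCc2ccc(-c3ccccc3C(=O)O)cc2)[nH]1` — 2710 nM

In an in vitro functional assay on cells for agonist activity at Bombesin receptor subtype-3 (Homo sapiens), read by luminescence and calcium flux (a higher number here means that more compound is needed for the effect, a lower number that less compound is needed), compound 2 gives the highest of the two numbers shown; the nearest is compound 1 with 41 nM. Among the compounds with values here, the single measured step, a 66-fold higher number from compound 1 to compound 2 (1.82 log units; beyond the scatter), went from a ring to a chain at this place. Compound 3 `O=C(O)c1ccccc1-c1ccc(CCc2ncc(CC3CC3)[nH]2)cc1` carries the change (cyclopropyl in place of propyl on a saturated chain carbon bound to an aromatic carbon), bringing back a ring, though only a three-membered one. Because a 66-fold higher number from compound 1 to compound 2 (1.82 log units; beyond the scatter) favoured the ring-bearing compound, a lower number is expected for compound 3, but a more modest drop. The expected step is a 2.1-fold lower number from compound 2 to compound 3 (0.32 log units; beyond the scatter). For compound 3 the estimate is 1300 nM, with a range from 350 nM to 5000 nM.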

Compound 3, half-maximal effective concentration: 1000 nM
Compound 3: the middle estimate sits 1.3-fold (0.11 log units) above what was measured, within the range that was stated.
By their numbers in this assay, from the lowest: compound 1; then compound 3; then compound 2.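

Swapping propyl for cyclopropyl at this place, with the same count of heavy atoms, gives a 2.7-fold lower number from compound 2 to compound 3 (0.43 log units; beyond the scatter) so closing the chain into a ring brings a real but modest gain. Cyclopropyl in place of cyclohexyl still costs a 24-fold higher number from compound 1 to compound 3 (1.39 log units; beyond the scatter) and so most of the advantage of compound 1 stays tied to the larger cyclohexyl ring, not to having any ring at all.

The compounds shown leave open where cyclobutyl or cyclopentyl would fall, and whether a phenyl ring could stand in for cyclohexyl. No measurement here explains either step.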